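Octyl chain series: trimming the terminal unit of compound 3

A few compounds are considered here, and "the series" means these few. Any claim that something is new, unique, unknown or untested is made for them only; others in the source may bear on it.

Measured in a physicochemical assay for lipophilicity, measured as octanol-water partition; a higher number here means a more lipophilic compound, a lower number a more polar compound:
Compound 1 `CCCCCCCCc1cn(C/C=C(/C)CCC=C(C)C)nn1`: 6.92
Compound 2 `CCCc1cn(C/C=C(\C)CCC=C(C)C)nn1`: 4.5
Compound 3 `CCCCCCCCc1cn(C/C=C(\C)CC/C=C(\C)CCC=C(C)C)nn1`: 8.76

Compound 3 holds the highest of the three numbers. Compound 1 lies nearest to it and compound 2 furthest, and both gaps are beyond the scatter.

The next compound is compound 4 `CCCCCCCCc1cn(C/C=C(\C)CCC=C(C)C)nn1`, not yet measured. The change is hydrogen in place of 3-methylbut-2-en-1-yl on a saturated chain carbon bound to a double-bonded chain carbon. Cut one bond further out, the same difference reads 2,6-dimethylhepta-1,5-dien-1-yl to 2-methylprop-1-en-1-yl.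

Going by the values given here, no single-place step between measured compounds is available to calibrate this change in this assay. The expectation therefore leans on compound 1 at 6.92, the nearest value under compound 3. A fall beyond the scatter is expected, with an estimated size of a number 1.86 log units lower from compound 3 to compound 4 (beyond the scatter). Compound 4 is estimated at 6.9, with an expected range of 6.5 to 7.3.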

Compound 4, partition coefficient: 6.92
Compound 4: the middle estimate sits 0.02 log units below what was measured; measured number inside the range.
By their numbers in this assay, from the lowest: compound 2; then compounds 1 and 4 (each within the scatter of the next); then compound 3.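

In this assay, hydrogen in place of 3-methylbut-2-en-1-yl on a saturated chain carbon bound to a double-bonded chain carbon gives a number 1.84 log units lower from compound 3 to compound 4 (beyond the scatter). Pentyl in place of hydrogen on a saturated chain carbon, three bonds along the chain from an aromatic carbon, gives a number 2.42 log units higher from compound 2 to compound 4 (beyond the scatter), so each of the two chains now has its own single-place step. With the double bond drawn Z and then E, the series shows no change at the digits printed from compound 1 to compound 4 (within the scatter), a reading that rests on this one pair: the fact that compounds 1 and 4 differ only in the configuration as drawn

The compounds shown leave open how an amine or a carboxylic acid in place of 3-methylbut-2-en-1-yl would read in this assay. Also open, on these data alone, is whether a longer chain in place of octyl would extend the step seen with pentyl, and whether the same configuration change would give the same reading on the longer chain of compound 3.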